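The source may hold more compounds than are shown below. What is called first, only, known or untested is meant among the compounds shown, and "the series" means these compounds.

Compound 1 `COCCOc1ccc(-c2c(N)c(C(=O)c3ccc(F)cc3F)cc[n+]2[O-])c(C)c1` gives 67 ug/mL. Compound 2 `Nc1c(C(=O)c2ccc(F)cc2F)cc[n+]([O-])c1-c1ccccc1Cl` gives 59 ug/mL.

Both numbers come from a physicochemical assay for solubility, at pH 7.4; on this read-out higher numbers stand for higher solubility and lower numbers for lower solubility. Compound 1 shows the larger of the two numbers, but the gap to compound 2 is within the scatter, so no order between the two can be claimed. Compound 3 `Cc1cc(C(=O)O)ccc1-c1c(N)c(C(=O)c2ccc(F)cc2F)cc[n+]1[O-]` has not yet been measured in this assay. It differs from compound 1 in one place: carboxy in place of 2-methoxyethoxy on an aromatic carbon. Within the data shown here, no step between measured compounds carries this change, so the two measured values give no direct guide to its size. The step is nonetheless expected to be upward and beyond the usual scatter, a 3.0-fold higher number from compound 1 to compound 3 (0.47 log units; beyond the scatter), on the reading that a carboxy group entering in place of a 2-methoxyethoxy group is more likely to raise than to lower this read-out. For compound 3 the estimate is 200 ug/mL, with a range from 60 ug/mL to 650 ug/mL.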

Compound 3, solubility: > 1000 ug/mL
Compound 3: a limit, no number; the forecaster's own chance of this, stated with the estimate: 10%; middle value at least 5.0-fold (0.69 log units) from the limit.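

In this assay compound 3 gives > 1000 ug/mL, which is a limit of the assay and not a number. Among these compounds, on this aromatic carbon, meta to a methyl group, carboxy in place of 2-methoxyethoxy brings an at least 14-fold higher number from compound 1 to compound 3 (1.17 log units; beyond the scatter), the first step at this position, as the earlier compounds offered no step between measured compounds that differ in one place. The size of this step is a bound rather than a measured distance, and the read-out has reached its ceiling here: the limit of > 1000 ug/mL in this assay, at which 1 of the 3 values shown sits.

From the compounds shown here alone, how far the step truly runs remains open. The compounds shown also leave open whether a methyl ester, a primary amide or an amine on the same carbon would move the read-out in the same direction as carboxy.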